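From a Propyl Chain to a Fluorophenyl Ring

This account rests on a few compounds, and the source may have more. Where it says the series, first, only, none or still open, it means among the compounds named here.

Compound 1 `CCCOc1ccccc1C1CC(=O)c2ccccc2O1` was tested in a functional assay on RAW264.7 cells (Mus musculus) for inhibition, read by immunoassay, with a stated time of 12 h, tested at 30 uM (a lower number here means less inhibition, a higher number more inhibition at the concentration tested (going by the name of the read-out)), where compound 1 gives 45.7%. Compound 2 `CCCCOc1ccccc1C1CC(=O)c2ccccc2O1` differs by a methyl in place of hydrogen on a saturated chain carbon, three bonds along the chain from an oxygen on an aromatic ring, and in this assay compound 2 gives 19.3%. For the measured compounds named here, that single change brings a number 26.4 percentage points lower from compound 1 to compound 2 (beyond the scatter), so compound 2 stands as the lower of the two numbers measured so far.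

Compound 3 `O=C1CC(c2ccccc2OCc2cccc(F)c2)Oc2ccccc21` is the next compound, and the change from compound 2 is 3-fluorophenyl in place of propyl on a saturated chain carbon bound to an oxygen on an aromatic ring. Going by the values given here, the only measured step, a number 26.4 percentage points lower from compound 1 to compound 2 (beyond the scatter), concerns a chain made one carbon longer; it says nothing directly about a ring carrying a fluorine entering in place of a propyl chain. Because inhibition fell in a number 26.4 percentage points lower from compound 1 to compound 2 (beyond the scatter) when the chain grew, a further drop cannot be ruled out, but a ring is a different kind of group and the data give no guide to it. The expected outcome for compound 3 is therefore a step of a number 5.7 percentage points higher from compound 2 to compound 3 (within the scatter), nothing clearly beyond the scatter. Compound 3 is estimated to give 25%, within a range from 5% to 55%.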

Compound 3, a percentage reported as inhibition, at one concentration (the size of the read-out at that concentration, not a potency): 93.3%
Beside the measured number, compound 3's estimate is 68.3 percentage points below it, outside the stated range (above it).
By their numbers in this assay, from the lowest: compound 2; then compound 1; then compound 3.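

At this place, on a saturated chain carbon bound to an oxygen on an aromatic ring, a ring and a chain do not behave alike: replacing propyl with 3-fluorophenyl brings a number 74 percentage points higher from compound 2 to compound 3 (beyond the scatter) and replacing ethyl with 3-fluorophenyl brings a number 47.6 percentage points higher from compound 1 to compound 3 (beyond the scatter) in this assay for these two changes. The earlier pair suggested that adding to the chain lowers the number, but compound 3 goes against that reading, since it carries the entering group with the most heavy atoms and still gives the highest number of the three, so more heavy atoms here do not by themselves mean less inhibition. No measurement at hand explains why this change has such a large effect.

The compounds shown cannot separate the part played by the ring from the part played by the fluorine, a question that an unsubstituted benzyl group or a chlorobenzyl group at the same place would help to answer. From the compounds shown here alone, it also remains open how a ring containing nitrogen, such as pyridine, or a chain ending in an amine would fare, and each number here describes a single tested concentration rather than a potency.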